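Adding tert-butoxycarbonyl to a ring amine

The source may report more compounds than this note shows. Statements on the series, on what has been measured and on what is new or still open speak of the compounds shown alone.

In an ADME assay on MCF7-DOX cells (Homo sapiens) for cytotoxicity, read by MTT assay, with a stated time of 48 h (on this read-out higher numbers stand for weaker inhibition and lower numbers for stronger inhibition), compound 1 (`COc1cc(O)c(C(=O)/C=C/c2ccc(N3CCNCC3)cc2)c(OC)c1`) gives 67500 nM while compound 2 (`COc1cc(OC)c(C(=O)/C=C/c2ccc(C(F)(F)F)cc2)c(O)c1CC=C(C)C`) gives 73700 nM and these two numbers lie within the usual scatter of each other. Compound 3 (`COc1cc(O)c(C(=O)/C=C/c2ccc(N3CCN(C(=O)OC(C)(C)C)CC3)cc2)c(OC)c1`) carries tert-butoxycarbonyl in place of hydrogen on an amine nitrogen in a ring. Going by the values given here, no measured pair shows this change, so the data offer no direct guide, and no step beyond the scatter is expected in this assay here. The expected step is a 1.1-fold lower number from compound 1 to compound 3 (0.05 log units; within the scatter) in size. For compound 3 the estimated value is 60000 nM with an expected range from 25000 nM to 130000 nM around it.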

Compound 3, half-maximal inhibitory concentration: 47300 nM
Estimate against measurement, compound 3: 1.3-fold (0.10 log units) above; low and high end bracket the measured number.
By their numbers in this assay, from the lowest: compounds 3, 1 and 2 (each within the scatter of the next).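

Placing tert-butoxycarbonyl in place of hydrogen on this amine nitrogen in a ring gives, in this assay, a 1.4-fold lower number from compound 1 to compound 3 (0.15 log units; within the scatter) as the first direct reading of this change. The hydrogen on that nitrogen can therefore be replaced by this larger group without the number moving beyond the scatter. Nothing available explains this result.
Going by these compounds, whether a methyl or acetyl group, or a longer chain ending in a carboxylic acid, on the same nitrogen would also stay within the scatter remains open. So does whether this step would hold on a different core.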